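The source may report more compounds than this note shows. Statements on the series, on what has been measured and on what is new or still open speak of the compounds shown alone.

Measured in a functional assay on KB cells (Homo sapiens) for cytotoxicity, read by sulforhodamine B assay; a lower number here means that less compound is needed, a higher number that more compound is needed for the effect:
Compound 1 `C=C1CC[C@@H]2[C@](C)(CO)[C@H](OC(C)=O)CC[C@@]2(C)[C@@H]1C/C=C1/C(=O)OC[C@H]1O` gives 35.7 uM.
Compound 2 `C=C1CC[C@@H]2[C@](C)(CO[Si](c3ccccc3)(c3ccccc3)C(C)(C)C)[C@H](OC(C)=O)CC[C@@]2(C)[C@@H]1C/C=C1/C(=O)OC[C@H]1OC(C)=O` gives 29 uM.
Compound 3 `C=C1CC[C@@H]2[C@](C)(COC(C)=O)[C@H](O)CC[C@@]2(C)[C@@H]1C/C=C1/C(=O)OC[C@H]1O` gives 15.3 uM.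

Compound 1 stands at the highest of the three numbers. Compound 2 sits within the scatter of it, so the two cannot be told apart, while compound 3 lies beyond the scatter at a lower number. Compound 4 `C=C1CC[C@@H]2[C@](C)(CO[Si](C)(C)C(C)(C)C)[C@H](OC(C)=O)CC[C@@]2(C)[C@@H]1C/C=C1/C(=O)OC[C@H]1O` is derived from compound 1 by a group of 7 heavy atoms (6 carbon, 1 silicon; no ring) in place of a hydrogen atom, on an oxygen on a saturated carbon. Within the data shown here, no pair of compounds differing in a single place has been measured, so the size of such a step is not directly known. Still, a change of similar kind is present in compound 2, which also carries a silicon-bearing group on that oxygen and gives 29 uM alongside a second alteration. The step is therefore expected to stay within the scatter, a 1.2-fold lower number from compound 1 to compound 4 (0.08 log units; within the scatter). Compound 4 is estimated at 30 uM, within 12 uM to 75 uM.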

Compound 4, concentration for half-maximal effect: 11.2 uM
Estimate against measurement, compound 4: 2.7-fold (0.43 log units) above, outside the stated range (below it).
By their numbers in this assay, from the lowest: compounds 4, 3, 2 and 1 (each within the scatter of the next, the first and the last beyond it).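

Read in this assay the exchange of a hydrogen atom for a group of 7 heavy atoms (6 carbon, 1 silicon; no ring), on an oxygen on a saturated carbon, gives a 3.2-fold lower number from compound 1 to compound 4 (0.50 log units; beyond the scatter) and is the first single-place step available here. This oxygen can therefore carry such a group without loss of effect, and the hydrogen on it is not needed. Nothing measured here bears on why the number falls.
Going by these compounds, whether the silicon matters remains open, since a methyl group or a benzyl group on the same oxygen could give a similar step or none.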